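The source may report more compounds than this note shows. Statements on the series, on what has been measured and on what is new or still open speak of the compounds shown alone.

Measured compounds and values:

- Compound 1 `Cc1cn2c(-c3cn[nH]c3)cnc2c(Nc2cc(Cn3cccc(C)c3=O)ns2)n1` — "not determined" (no result reported) in an ADME assay on the whole organism for pharmacokinetics, with Rattus norvegicus as the target, with a stated time of 6 h, at a dose of 10 mg/kg by the oral route; a higher number here means more compound in the circulation at the dose given, a lower number less compound in the circulation (no number reported)
- Compound 2 `Cc1cn2c(-c3cn[nH]c3)cnc2c(Nc2cc(C(c3ccccn3)N3CCCC3)ns2)n1` — 9.15 ng.h/mL in this assay

Going by the values given here, compound 2 gives the only number in the set; in this assay compound 2 gives 9.15 ng.h/mL. Compound 1 carries no result there, so compound 2 stands alone and no step between measured compounds can be stated from what is shown.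

Compound 3 `Cc1cn2c(-c3cn[nH]c3)cnc2c(Nc2cc(C(c3ccccn3)N3CCC(F)CC3)ns2)n1` has not yet been measured. It differs from compound 2 in one place: 4-fluoropiperidin-1-yl in place of pyrrolidin-1-yl on a saturated chain carbon bound to two aromatic carbons.

With no measured step of this kind in the series, there is no basis for expecting a shift beyond the usual scatter in either direction. The working expectation is that compound 3 will land close to compound 2, and the estimated step from compound 2 to compound 3 is a 1.3-fold higher number from compound 2 to compound 3 (0.12 log units; within the scatter), within scatter. Compound 3 is therefore expected to give about 12 ng.h/mL in this assay, with a plausible range from 3 ng.h/mL to 50 ng.h/mL.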

Compound 3, area under the concentration-time curve: 220 ng.h/mL
Estimate against measurement, compound 3: 18-fold (1.26 log units) below; the measured number lies above the stated range.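

In this assay, going by these compounds alone, the saturated chain carbon bound to two aromatic carbons is the first place where a single change can be read, and 4-fluoropiperidin-1-yl in place of pyrrolidin-1-yl gives a 24-fold higher number from compound 2 to compound 3 (1.38 log units; beyond the scatter). The shared core and the rest of the structure stay the same, so this position is not silent for the amount of compound in the circulation: the change at this one place is enough to move the number well beyond the scatter. The step joins two changes, a six-membered ring for a five-membered one and the added fluorine, and nothing available bears on why the number moved.

Which of the two changes carries the step stays open, and a plain piperidin-1-yl group at the same place would separate them. An open-chain dimethylamino group or a morpholine ring there would show whether the higher number is tied to 4-fluoropiperidin-1-yl alone or extends to other amines.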